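A few compounds are considered here, and "the series" means these few. Any claim that something is new, unique, unknown or untested is made for them only; others in the source may bear on it.

Notes on compound 4 (`O=[N+]([O-])c1ccc(-c2cc(-c3ccc(O)cc3)no2)cc1`), starting from compound 2 (`COc1ccc(-c2cc(-c3ccc([N+](=O)[O-])cc3)on2)cc1`). In an ADME assay (Mus musculus) for antiproliferative activity, read by cell counting, with a stated time of 5 days (on this read-out higher numbers stand for weaker inhibition and lower numbers for stronger inhibition), compound 2 gives > 100000 nM, which is a limit of the assay and not a number. Compound 1 (`COc1ccc(-c2cc(-c3ccc(OC)cc3)on2)cc1`) also gives only a limit (> 100000 nM). The readings so far thus rest largely on the limit of > 100000 nM in this assay, at which 2 of the 3 values shown sit, and offer little to scale from.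

The change to compound 4 is hydrogen in place of methyl on an oxygen on an aromatic ring, or methoxy to hydroxy. Among the measured compounds shown here, the one measured step, a step that the two limits leave unreadable from compound 1 to compound 2, is a different change and gives no size to carry over. For the measured compounds named here, compound 3 (`CCc1c(-c2ccc(O)cc2)noc1-c1ccc(O)cc1`), which carries hydroxy, gives the only number (13000 nM), but it differs from compound 2 in more than one place. On that single value for compound 3, a modest move towards stronger inhibition in this assay is expected, and a second limit reading remains quite possible. The estimated step is an at least 2.5-fold lower number from compound 2 to compound 4 (0.39 log units; beyond the scatter) in that direction. The estimated value for compound 4 is 40000 nM (expected range 12000 nM to 100000 nM).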

Compound 4, half-maximal inhibitory concentration: 42000 nM
For compound 4 the middle estimate is 1.1-fold (0.02 log units) below the measured one; the range from low to high includes it.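

In this assay, hydrogen in place of methyl on an oxygen on an aromatic ring gives the first readable step in the series, an at least 2.3-fold lower number from compound 2 to compound 4 (0.37 log units; beyond the scatter), and methoxy to hydroxy is thus the one change shown that moves a reading off the limit. Compound 2 gives > 100000 nM, which is a limit of the assay and not a number. The step therefore fixes only a smallest size, and the true size remains unknown: the limit of > 100000 nM in this assay, at which 2 of the 4 values shown sit.

On these data alone, whether an amine or a carboxylic acid in place of hydroxy at this position would keep, enlarge or lose the step remains open. As far as these compounds go, it is also open whether methoxy to hydroxy would give a step of similar size on compound 1, which carries methoxy in place of nitro.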